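Compound 2 to compound 4: exchange of the aryl group

This account rests on a few compounds, and the source may have more. Where it says the series, first, only, none or still open, it means among the compounds named here.

Compound 2 (`COc1ccc(C(F)(F)F)cc1Nc1ncc(C(F)(F)F)c(N2Cc3cccc(N(C)S(C)(=O)=O)c3C2)n1`) gives > 30000 nM in a functional assay on HepG2 cells (Homo sapiens) for antiproliferative activity, read by spectrophotometry, with a stated time of 2 days (on this read-out lower numbers stand for stronger inhibition of growth and higher numbers for weaker inhibition of growth), and that reading is a limit, not a number. Compound 1 (`COc1ccc(Nc2ncc(C(F)(F)F)c(N3Cc4cccc(N(C)S(C)(=O)=O)c4C3)n2)cc1C(F)(F)F`) gives > 30000 nM in this assay and this too is only a limit. Going by the values given here, the one measured step is a step that the two limits leave unreadable from compound 1 to compound 2 and it offers no size to carry forward. Among the compounds with values here, the only number comes from compound 3 (`COc1cc(N2CCN(C(C)=O)CC2)ccc1Nc1ncc(C(F)(F)F)c(N2Cc3cccc(N(C)S(C)(=O)=O)c3C2)n1`), which gives 3800 nM with another aryl group on that nitrogen.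

Compound 4 (`COc1cc(Nc2ncc(C(F)(F)F)c(N3Cc4cccc(N(C)S(C)(=O)=O)c4C3)n2)c(OC)cc1Cl`) carries 4-chloro-2,5-dimethoxyphenyl in place of 2-methoxy-5-(trifluoromethyl)phenyl on a nitrogen on an aromatic ring. No measured step sizes this exchange. Compound 1 and compound 2 both stand at the limit of > 30000 nM in this assay, at which 2 of the 3 values shown sit, so no step beyond the scatter is expected in this assay and growth inhibition is expected to stay weak. The estimated a number no higher from compound 2 to compound 4 (the limit leaves the size open) is accordingly no clear change in either direction. For compound 4 the estimate is 30000 nM with an expected range of 12000 nM to 60000 nM and a report as a limit is likely.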

Compound 4, concentration for 50% growth inhibition: 25600 nM
The estimate for compound 4 lay 1.2-fold (0.07 log units) above the measured number; measured number inside the range.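

In this assay compound 4 gives 25600 nM, a measured number rather than a limit, which neither compound 1 nor compound 2 gave, so with 4-chloro-2,5-dimethoxyphenyl on this nitrogen the growth inhibition becomes readable. Exchanging the aryl group gives an at least 1.1-fold lower number from compound 2 to compound 4 (0.06 log units; that floor lies within the scatter), and the parallel exchange gives an at least 1.1-fold lower number from compound 1 to compound 4 (0.06 log units; that floor lies within the scatter), so no gain beyond the scatter is established. The true size of both steps stays open because each starts from a limit, not a number: the limit of > 30000 nM in this assay, at which 2 of the 4 values shown sit.

The compounds shown do not separate the chloro group from the two methoxy groups as the source of the readable value for compound 4. On these data alone, compound 3 gives 3800 nM with a different aryl group on this nitrogen, and the effect of a morpholine or a carboxylic acid in place of the chlorine remains open.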